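Phenyl for methyl on a thiazole hydrazone

A few compounds are considered here, and "the series" means these few. Any claim that something is new, unique, unknown or untested is made for them only; others in the source may bear on it.

Of the compounds shown here, two of this hydrazone series have numbers so far. Compound 1 `C(=N/Nc1nc(-c2ccccc2)cs1)\c1ccccc1` gives 1200 nM in an assay on mitochondria for inhibition of Amine oxidase [flavin-containing] A (Bos taurus); on this read-out higher numbers stand for weaker inhibition and lower numbers for stronger inhibition. Compound 2 `COc1ccc(/C=N/Nc2nc(C)cs2)cc1` gives 19.1 nM in this assay, the lower of the two numbers and thus the stronger inhibitor of the pair, with the gap to compound 1 well beyond the scatter. Within the data shown here, the two compounds differ in two places at once, so no single step between them can be read off.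

Compound 3 `COc1ccc(/C=N/Nc2nc(-c3ccccc3)cs2)cc1` keeps the methoxy-bearing aryl of compound 2 and changes only the small group on the shared core: phenyl in place of methyl on an aromatic carbon. Nothing measured isolates what this exchange alone does, and compound 1, which also carries a phenyl on its core, lacks the methoxy group, so its weaker number cannot be assigned to either change. On balance, a modest loss of potency seems more likely than a gain, but a result within the scatter would not surprise. The step from compound 2 to compound 3 is therefore expected to be a 3.1-fold higher number from compound 2 to compound 3 (0.50 log units; beyond the scatter). Compound 3 is expected to give about 60 nM, within a range from 10 nM to 600 nM.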

Compound 3, inhibition constant: 50.1 nM
Beside the measured number, compound 3's estimate is 1.2-fold (0.08 log units) above it, within the range that was stated.
By their numbers in this assay, from the lowest: compound 2; then compound 3; then compound 1.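

Among these compounds, with compound 3 in place, the exchange of methyl for phenyl next to the ring nitrogen can be read on its own for the first time: this assay shows a 2.6-fold higher number from compound 2 to compound 3 (0.42 log units; beyond the scatter) as a modest step, so a compound carrying the larger phenyl group at this carbon still gives a number far lower than that of compound 1. Compound 3 also isolates the other change that had been tangled up in the earlier pair, since methoxy in place of hydrogen on an aromatic carbon, with phenyl on the core in both compounds, gives a 24-fold lower number from compound 1 to compound 3 (1.38 log units; beyond the scatter) as a large step and so has the bigger effect of the two single changes now readable. Nothing available here accounts for the size of either step.

The compounds shown leave open how an ethyl chain, a cyclohexyl ring or a phenyl bearing a carboxylic acid would fare on this same carbon of the core. They also leave open whether methoxy gives a step of similar size when the core carries methyl instead of phenyl, and whether an amine or a hydroxyl group could stand in for the methoxy.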